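The source may report more compounds than this note shows. Statements on the series, on what has been measured and on what is new or still open speak of the compounds shown alone.

Compound 1 `CN1CCC(CNS(=O)(=O)c2ccccc2Nc2cc(-c3ccc4ccn(C)c4c3)c3nccnc3c2)C1` gives 4640 nM in an assay on lysate for inhibition of 6-phosphofructo-2-kinase/fructose-2,6-bisphosphatase 3 (Homo sapiens), with stated times of 0.5 min and 45 min; on this read-out lower numbers stand for stronger inhibition and higher numbers for weaker inhibition. Compound 2 `Cn1ccc2ccc(-c3cc(Nc4ccccc4S(=O)(=O)Nc4cncnc4)cc4nccnc34)cc21` carries pyrimidin-5-yl on the sulfonamide nitrogen instead. In this assay compound 2 gives > 100000 nM, which is a limit of the assay; it sits at the limit of > 100000 nM in this assay, at which 1 of the 2 values shown sits. Going by the values given here, the only measured step in this assay is an at least 21-fold higher number from compound 1 to compound 2 (1.33 log units; beyond the scatter). Compound 3 `CN1CCC(NS(=O)(=O)c2ccccc2Nc2cc(-c3ccc4ccn(C)c4c3)c3nccnc3c2)C1` differs from compound 2 by 1-methylpyrrolidin-3-yl in place of pyrimidin-5-yl on a sulfonamide nitrogen, which largely undoes that step, so a large move to lower numbers is expected, an at least 16-fold lower number from compound 2 to compound 3 (1.22 log units; beyond the scatter). Compound 3 is therefore estimated at 6000 nM in this assay, with a range from 1500 nM to 30000 nM.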

Compound 3, half-maximal inhibitory concentration: 3160 nM
Compound 3: the middle estimate sits 1.9-fold (0.28 log units) above what was measured; low and high end bracket the measured number.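

On the sulfonamide nitrogen, 1-methylpyrrolidin-3-yl in place of pyrimidin-5-yl gives an at least 31-fold lower number from compound 2 to compound 3 (1.50 log units; beyond the scatter). Setting the ring directly on that nitrogen rather than through the (1-methylpyrrolidin-3-yl)methyl chain shows no readable difference, with a 1.5-fold lower number from compound 1 to compound 3 (0.17 log units; within the scatter). The true size of the step away from compound 2 stays unknown, since the value of compound 2 is a limit of the assay: the limit of > 100000 nM in this assay, at which 1 of the 3 values shown sits.

Open, from the compounds shown here alone, is whether the ring nitrogen is needed, which a cyclopentyl group on the sulfonamide nitrogen would test. Also open, going by these compounds, is whether a piperidin-4-yl group or a longer chain ending in a dimethylamine would give clearly lower numbers.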